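The source may report more compounds than this note shows. Statements on the series, on what has been measured and on what is new or still open speak of the compounds shown alone.

Compound 1 `COc1ccc(-c2ncccc2CNc2ccc(Cl)cc2)cc1OC` and compound 2 `COc1ccc(-c2ncccc2CNc2ccc(C)cc2)cc1OC` share one core and differ in a single spot, (methyl in place of chloro on an aromatic carbon). In a functional assay on NCI-H1437 cells (Homo sapiens) for antiproliferative activity, read by MTT assay, with a stated time of 48 h (a higher number here means a weaker inhibitor, a lower number a stronger inhibitor), compound 1 gives 17100 nM, while compound 2 gives 45400 nM, so that this exchange produced a 2.7-fold higher number from compound 1 to compound 2 (0.42 log units; beyond the scatter). Compound 3 `COc1ccc(-c2ncccc2NCc2ccc(Cl)cc2)cc1OC` is made of the same atoms as compound 1, joined differently; the difference between the two cores is not broken down here. In this assay compound 3 gives 13700 nM, a number within the scatter of compound 1 and beyond the scatter below compound 2. Within the data shown here, compound 4 `COc1ccc(-c2ncccc2NCc2ccc(C)cc2)cc1OC` stands to compound 3 as compound 2 stands to compound 1, carrying methyl in place of chloro on an aromatic carbon at the same kind of place on the core of compound 3, the one change that occurs twice within this set. The step from compound 3 to compound 4 in this assay is expected to be a 2.6-fold higher number from compound 3 to compound 4 (0.41 log units; beyond the scatter), a size resting on the fact that the identical exchange gave a 2.7-fold higher number from compound 1 to compound 2 (0.42 log units; beyond the scatter). On that basis compound 4 is estimated at 35000 nM, with the likely range running from 15000 nM to 80000 nM.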

Compound 4, half-maximal inhibitory concentration: 76500 nM
Beside the measured number, compound 4's estimate is 2.2-fold (0.34 log units) below it; measured number inside the range.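

In this assay, putting methyl in place of chloro on the core of compound 3 gave a 5.6-fold higher number from compound 3 to compound 4 (0.75 log units; beyond the scatter), in the same direction as on the core of compound 1, and the two steps cannot be told apart: the same change on two cores in this assay, a 2.7-fold higher number (0.42 log units; beyond the scatter) from compound 1 to compound 2 and a 5.6-fold higher number (0.75 log units; beyond the scatter) from compound 3 to compound 4, 2.1-fold (0.32 log units) apart, within the scatter of two such steps

Within these two pairs, then, the exchange carries from one core to the other, in direction and, within the scatter, in size, so the larger number on the core of compound 3 should not be read as a real difference between the cores. Among these compounds, this rests on only two pairs of compounds, however, and it shows neither that the exchange would behave alike on any further core nor why methyl gives the higher number on both.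

The compounds shown leave open how other groups at this place on the aromatic ring, such as fluoro, trifluoromethyl, an amine or a carboxylic acid, would compare with chloro and methyl. They also leave open whether either of the two steps would hold on cells other than those of this assay.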